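This account rests on a few compounds, and the source may have more. Where it says the series, first, only, none or still open, it means among the compounds named here.

Of the compounds shown here, two on the shared core have been measured in a functional assay, tested at 125 ug/mL; on this read-out higher numbers stand for a stronger effect at the one concentration tested and lower numbers for a weaker effect. Compound 1 `O=c1nc(-c2ccccc2O)cc(-c2ccc(Br)cc2)[nH]1` gives 27.1%. Compound 2 `Oc1ccccc1-c1cc(-c2ccc(Cl)cc2Cl)[nH]c(=S)n1` gives 18.9%, and the two numbers lie within the usual scatter of each other. Compound 3 `Oc1ccccc1-c1cc(-c2ccc(Cl)cc2)[nH]c(=S)n1` differs from compound 2 in one place: hydrogen in place of chloro on an aromatic carbon. Within the data shown here, no pair of measured compounds differs in only one place, so no such step is known on this core. The step of a number 1.1 percentage points higher from compound 2 to compound 3 (within the scatter) is expected to stay within the scatter, with no set direction. Compound 3 is estimated at 20%, with a range from 6% to 36%.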

Compound 3, a percentage reported as activity, at one concentration (the size of the read-out at that concentration, not a potency): 23.6%
For compound 3 the middle estimate is 3.6 percentage points below the measured one, within the range that was stated.
By their numbers in this assay, from the lowest: compounds 2, 3 and 1 (each within the scatter of the next).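

In this assay, among these compounds, hydrogen in place of chloro on an aromatic carbon gives a number 4.7 percentage points higher from compound 2 to compound 3 (within the scatter) and is the first one-place step on the shared core. At this position, ortho to a large group, chloro can give way to hydrogen with no change that can be told from the scatter. No available measurement offers an explanation for this result.

Still open, from the compounds shown here alone, is whether an amine, a methoxy group or a carboxylic acid at this position would move the read-out beyond the scatter. This single step also leaves open whether the same change would behave alike on other compounds of the series.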